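Taking One Chlorine Off a Dichlorophenyl Sulfonamide

The compounds below may be only part of what the source reports. "The series", "measured", "known", "first", "only" and "open" are said of these compounds alone.

Compound 1 `O=S(=O)(Nc1ccc(Cl)c(Cl)c1)c1ccc(-c2cnc(C3CC3)o2)cc1` gives 416 nM
Compound 2 `O=S(=O)(Nc1ccc(Cl)cc1Cl)c1ccc(-c2cnc(C3CC3)o2)cc1` gives 481 nM

In a functional assay on cells (leukaemia cell line, Homo sapiens) for inhibition, read by sulforhodamine B assay, with a stated time of 48 h (a higher number here means a weaker inhibitor of growth, a lower number a stronger inhibitor of growth), compound 2 gives 481 nM and cannot be told apart from compound 1 on these numbers. Within the data shown here, only one measured step is available, and it is a 1.2-fold higher number from compound 1 to compound 2 (0.06 log units; within the scatter) with 2,4-dichlorophenyl in place of 3,4-dichlorophenyl on a sulfonamide nitrogen. That step trades one dichlorophenyl for another, so it does not show what happens when a chloro is taken away.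

Compound 3 `O=S(=O)(Nc1ccccc1Cl)c1ccc(-c2cnc(C3CC3)o2)cc1` brings exactly that kind of change, namely hydrogen in place of chloro on an aromatic carbon with hydrogen in place of chloro on an aromatic carbon. Read one bond further out, this is 2,4-dichlorophenyl to 2-chlorophenyl. Among the measured compounds shown here, no measured pair shows a chloro being removed, so the size of this step is poorly known. A modest rise in the number, meaning somewhat weaker growth inhibition, is expected, although a result within the scatter would be no surprise. The expected change is a 1.5-fold higher number from compound 2 to compound 3 (0.16 log units; within the scatter) in this estimate. For compound 3 the estimated value is 700 nM with an expected range from 260 nM to 1900 nM in this assay measurements.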

Compound 3, concentration for 50% growth inhibition: 429 nM
Compound 3: the middle estimate sits 1.6-fold (0.21 log units) above what was measured; the range from low to high includes it.
By their numbers in this assay, from the lowest: compounds 1, 3 and 2 (each within the scatter of the next).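

Here a chloro really is taken away, and in this assay the change from 2,4-dichlorophenyl to 2-chlorophenyl gives a 1.1-fold lower number from compound 2 to compound 3 (0.05 log units; within the scatter) and so no readable gain or loss of growth inhibition. Compound 3 also carries one chloro fewer than compound 1, and that comparison with the 3,4-dichlorophenyl group gives a 1.0-fold higher number from compound 1 to compound 3 (0.01 log units; within the scatter) as well, so the three compounds cannot be told apart. Among these three, then, a second chloro on this ring is not needed to keep the number where it stands, and nothing on hand explains why.

As far as these compounds go, all three compounds keep at least one chloro on this ring, so it remains open whether a plain phenyl group, with hydrogen in place of the last chloro, would stay in the same range. Among these compounds, also open is what a quite different group at this position, such as an amine or a carboxylic acid, would do in this assay to the number, since a chloro and a hydrogen are the only groups compared here.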